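This account rests on a few compounds, and the source may have more. Where it says the series, first, only, none or still open, it means among the compounds named here.

In a functional assay on MCF7 cells (Homo sapiens) for cytotoxicity, read by MTT assay, with a stated time of 72 h (on this read-out lower numbers stand for stronger inhibition and higher numbers for weaker inhibition), compound 3 (`CNC(=O)c1cc(Oc2ccc(NC(=O)c3cc(-c4ccccc4)ncn3)cc2)ccn1`) gives 18200 nM and compound 1 (`CNC(=O)c1cc(Oc2ccc(NC(=O)c3cc(-c4ccc(C)cc4)ncn3)cc2)ccn1`) gives 34600 nM, and these two values lie within the scatter of each other. Compound 2 (`CNC(=O)c1cc(Oc2ccc(NC(=O)c3cc(-c4ccc(Br)cc4)ncn3)cc2)ccn1`) reads > 100000 nM, which is a limit of the assay. Compound 4 (`CNC(=O)c1cc(Oc2ccc(NC(=O)c3cc(-c4ccc(F)cc4)ncn3)cc2)ccn1`) differs from compound 3 by fluoro in place of hydrogen on an aromatic carbon, phenyl to 4-fluorophenyl. Two measured steps exchange a group on that same aromatic carbon: methyl gives a 1.9-fold lower number from compound 1 to compound 3 (0.28 log units; within the scatter), whereas bromo gives an at least 5.4-fold lower number from compound 2 to compound 3 (0.73 log units; beyond the scatter). Neither step involves fluoro, so they set only loose bounds. A small rise in this assay, not beyond the scatter, is expected, and the estimated step is a 1.4-fold higher number from compound 3 to compound 4 (0.14 log units; within the scatter). For compound 4 the expected value is 25000 nM, within an estimated range of 10000 nM to 60000 nM.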

Compound 4, half-maximal inhibitory concentration: > 100000 nM
Compound 4 gave a limit, no number; the forecaster's own chance of this, stated with the estimate: 10%; middle value at least 4.0-fold (0.60 log units) away from the limit.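

In this assay, fluoro in place of hydrogen gives an at least 5.4-fold higher number from compound 3 to compound 4 (0.73 log units; beyond the scatter), and fluoro in place of methyl gives an at least 2.8-fold higher number from compound 1 to compound 4 (0.46 log units; beyond the scatter), so at this carbon the rise is no longer seen with bromo alone. A single fluorine atom is enough for it. The step between compound 2 and compound 4 cannot be read, as both are limits: the limit of > 100000 nM in this assay, at which 2 of the 4 values shown sit.

Going by these compounds, how far compound 2 and compound 4 really differ stays open. So does what chloro, methoxy or an amine would do at this carbon.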